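Swapping the ring on the thiazolidinone nitrogen of compound 2

This account rests on a few compounds, and the source may have more. Where it says the series, first, only, none or still open, it means among the compounds named here.

Compound 2 `COc1cccc(OC)c1N1C(=O)CSC1c1cccc(C(=O)NCCCCc2ccccc2)c1` gives only a limit, not a number, in a functional assay on HOS-TE85 cells (Homo sapiens) for inhibition, read by CCK-8 assay, with a stated time of 72 h (on this read-out lower numbers stand for stronger inhibition and higher numbers for weaker inhibition), being reported as > 1000 nM; it is the one case at the limit of > 1000 nM in this assay, at which 1 of the 3 values shown sits. Its companions fare better: compound 1 `COc1ccccc1N1C(=O)CSC1c1cccc(C(=O)NCCCCc2ccc(Cl)cc2)c1` gives 78.6 nM in this assay, and compound 3 `COc1ccccc1N1C(=O)CSC1c1cc(F)cc(C(=O)NCCCCc2ccccc2)c1` gives 40.9 nM. Compound 4 `O=C(NCCCCc1ccccc1)c1cccc(C2SCC(=O)N2c2ccc(C3CC3)cc2)c1` is not yet measured, and it differs from compound 2 by 4-cyclopropylphenyl in place of 2,6-dimethoxyphenyl on an amide-type nitrogen in a ring. Since compound 2 sits at the limit while compound 1 and compound 3 carry a single methoxy group and give numbers well inside the range, the step from compound 2 to compound 4 is expected to be downward and beyond the scatter, an at least 6.6-fold lower number from compound 2 to compound 4 (0.82 log units; beyond the scatter). Compound 4 is therefore estimated at 150 nM, in the range 40 nM to 600 nM.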

Compound 4, half-maximal inhibitory concentration: 217 nM
Compound 4: the middle estimate sits 1.4-fold (0.16 log units) below what was measured, within the range that was stated.
By their numbers in this assay, from the lowest: compounds 3 and 1 (each within the scatter of the next); then compound 4. At a limit, above all of these: compound 2.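

On the amide-type nitrogen in a ring, 4-cyclopropylphenyl in place of 2,6-dimethoxyphenyl gives an at least 4.6-fold lower number from compound 2 to compound 4 (0.66 log units; beyond the scatter) in this assay. This is the first one-place change shown at this position, and it shows that a ring carrying no methoxy group can still give a number here. The size of the step is only a lower bound, since compound 2 stands at a limit: the limit of > 1000 nM in this assay, at which 1 of the 4 values shown sits.

On these data alone, whether the drop comes from losing the 2,6-dimethoxyphenyl or from gaining the cyclopropyl remains open. As far as these compounds go, how a plain phenyl, or a phenyl bearing an amine or a carboxylic acid, would read out at this position also remains open.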